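Amide nitrogen substituent change from carboxyalkyl to ethoxyphenyl

This account rests on a few compounds, and the source may have more. Where it says the series, first, only, none or still open, it means among the compounds named here.

Compound 1 `CCn1c(C(=O)N(C)CCC#N)ccc1C(CC)(CC)c1ccc(OCC(O)C(C)(C)C)c(C)c1` gives 1960 nM in an assay on HL-60 cells for agonist activity at vitamin D3 receptor (Homo sapiens), read by microscopy, with a stated time of 96 h; a higher number here means that more compound is needed for the effect, a lower number that less compound is needed.
Compound 2 `CCn1c(C(=O)N(C)c2ccccc2)ccc1C(CC)(CC)c1ccc(OCC(O)C(C)(C)C)c(C)c1` gives 6400 nM in this assay.
Compound 3 `CC[C@@H](C)[C@H](NC(=O)c1ccc(C(CC)(CC)c2ccc(OCC(O)C(C)(C)C)c(C)c2)n1CC)C(=O)O` gives 2.3 nM in this assay.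

Compound 3 stands lowest of the three numbers: compound 1 is nearest, with an 850-fold lower number from compound 1 to compound 3 (2.93 log units; beyond the scatter), and compound 2 is furthest, with a 2800-fold lower number from compound 2 to compound 3 (3.44 log units; beyond the scatter). The difference between compound 1 and compound 2 is smaller, a 3.3-fold higher number from compound 1 to compound 2 (0.51 log units; beyond the scatter), so the shared core with a plain amide sits well above compound 3 whatever the second amide substituent.

Compound 4 `CCOc1ccc(NC(=O)c2ccc(C(CC)(CC)c3ccc(OCC(O)C(C)(C)C)c(C)c3)n2CC)cc1` differs from compound 3 by 4-ethoxyphenyl in place of 1-carboxy-2-methylbutyl on an amide-type nitrogen. The two steps that bear on this are those leading into compound 3 from compound 1 and from compound 2, both large; the step from compound 2 to compound 3 is the closest comparison, since compound 2 also carries a phenyl on that nitrogen, though together with a methyl. Compound 4 keeps the amide hydrogen that compound 1 and compound 2 lack, so the data do not pin it exactly. It is therefore expected that compound 4 moves back towards the range of compound 1 and compound 2, a large step up in this assay, a 520-fold higher number from compound 3 to compound 4 (2.72 log units; beyond the scatter). Compound 4 is estimated at 1200 nM, with a range from 150 nM to 8000 nM.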

Compound 4, half-maximal effective concentration: 630 nM
Estimate against measurement, compound 4: 1.9-fold (0.28 log units) above; the measured number falls inside the stated range.
By their numbers in this assay, from the lowest: compound 3; then compound 4; then compound 1; then compound 2.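

In this assay, the new result shows that an aromatic group on the amide-type nitrogen, even with the amide hydrogen kept, does not replace 1-carboxy-2-methylbutyl: there is a 270-fold higher number from compound 3 to compound 4 (2.44 log units; beyond the scatter). Compound 4 nevertheless improves on both compounds with a fully substituted amide nitrogen, with a 10-fold lower number from compound 2 to compound 4 (1.01 log units; beyond the scatter) and a 3.1-fold lower number from compound 1 to compound 4 (0.49 log units; beyond the scatter), although each of these steps changes more than one feature of the amide substituent. No measured evidence is available to explain these differences.

The compounds shown do not separate the contribution of the amide hydrogen from that of the ethoxy group in compound 4. They also leave open whether a 4-carboxyphenyl group would match compound 3, or whether a branched alkyl chain lacking the carboxylic acid would do so.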